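A few compounds are considered here, and "the series" means these few. Any claim that something is new, unique, unknown or untested is made for them only; others in the source may bear on it.

In an ADME assay on the whole organism (Mus musculus, strain Swiss Webster) for pharmacokinetics, read by LC-MS, at a dose of 50 mg/kg by the oral route (on this read-out higher numbers stand for higher exposure at the dose given and lower numbers for lower exposure), compound 1 (`O=C(Nc1ccc(F)c(-c2nc3ncc(-c4ccc(F)cc4F)cc3[nH]2)c1)N1CCCC1`) gives 9500 nM and compound 2 (`O=C(Nc1ccc(F)c(-c2nc3ncc(-c4cccc(F)c4)cc3[nH]2)c1)N1CCCC1`) gives 7000 nM. These two numbers lie within the scatter of each other, so compound 2 cannot be separated from compound 1 on this read-out.

The next member of the series is compound 3 (`O=C(Nc1ccc(F)c(-c2nc3ncc(-c4ccccc4F)cc3[nH]2)c1)N1CCCC1`), which has 2-fluorophenyl in place of 3-fluorophenyl on an aromatic carbon. For the measured compounds named here, only one measured step bears on this change, as it falls on the same aromatic carbon: a 1.4-fold lower number from compound 1 to compound 2 (0.13 log units; within the scatter). Going by the values given here, no measured pair compares the 2-fluorophenyl and 3-fluorophenyl groups directly, so this evidence is indirect and limited to one step.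

In this assay, the expected change is a 1.1-fold higher number from compound 2 to compound 3 (0.06 log units; within the scatter), with no step beyond the scatter anticipated in either direction. Compound 3 is estimated at 8000 nM, with an expected range of 3800 nM to 16000 nM.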

Compound 3, maximal plasma concentration: 2230 nM
Estimate against measurement, compound 3: 3.6-fold (0.55 log units) above, outside the stated range (below it).
By their numbers in this assay, from the lowest: compound 3; then compounds 2 and 1 (each within the scatter of the next).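

This position is more sensitive than compounds 1 and 2 suggested: in this assay, moving the single fluoro gives a 3.1-fold lower number from compound 2 to compound 3 (0.50 log units; beyond the scatter), so 2-fluorophenyl and 3-fluorophenyl are not interchangeable despite their identical atoms. Compound 3 also lies under the 2,4-difluorophenyl analogue, with hydrogen in place of fluoro giving a 4.3-fold lower number from compound 1 to compound 3 (0.63 log units; beyond the scatter). A 2-fluoro substituent therefore does not by itself mark low exposure, as compound 1 carries one and stands with compound 2 at the top of the set. Nothing measured here explains the drop.

From the compounds shown here alone, it remains open whether unsubstituted phenyl or 4-fluorophenyl would sit with compound 3 or with compounds 1 and 2. Equally open, going by these compounds, is whether a chloro or methoxy group would follow the fluoro pattern on this ring.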